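From Dimethoxyphenyl to Dihydroxyphenyl: An Unmeasured Analogue

The compounds below may be only part of what the source reports. "The series", "measured", "known", "first", "only" and "open" are said of these compounds alone.

Compound 1, `COc1ccc(OC)c(-c2cc(-c3ccccc3)nn2-c2ccc(S(N)(=O)=O)cc2)c1`: 32900 nM
Compound 2, `COc1ccc(OC)c(-c2cc(-c3ccccc3)nn2-c2ccc(S(=O)(=O)NC(C)=O)cc2)c1`: 44500 nM
Compound 3, `COc1ccc(OC)c(-c2cc(-c3ccc(Cl)cc3)nn2-c2ccc(S(=O)(=O)NC(C)=O)cc2)c1`: 70200 nM

These three compounds were tested in a functional assay on cells (Cancer cell lines, Homo sapiens) for cytotoxicity, read by sulforhodamine B assay, with a stated time of 48 h; a lower number here means a stronger inhibitor of growth, a higher number a weaker inhibitor of growth. Compound 2 has the second highest of the three numbers, but the step of a 1.4-fold higher number from compound 1 to compound 2 (0.13 log units; within the scatter) and the step of a 1.6-fold higher number from compound 2 to compound 3 (0.20 log units; within the scatter) both fall within the scatter, so the three values cannot be told apart with confidence. The measured changes, an acetyl on the sulfonamide nitrogen and a chloro on the phenyl ring, each left the number essentially where it was.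

Compound 4, `CC(=O)NS(=O)(=O)c1ccc(-n2nc(-c3ccccc3)cc2-c2cc(O)ccc2O)cc1`, differs from compound 2 by 2,5-dihydroxyphenyl in place of 2,5-dimethoxyphenyl on an aromatic carbon. Neither measured step touches this part of the molecule, so there is no direct guide to the effect of removing the two methyl groups. What the data do show is that two changes at other positions of the shared core produced no step beyond the scatter in this assay. On that basis the expected step from compound 2 to compound 4 is a 1.3-fold lower number from compound 2 to compound 4 (0.10 log units; within the scatter), with wide uncertainty in either direction. Compound 4 is therefore estimated at 35000 nM, within a range from 9000 nM to 130000 nM.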

Compound 4, concentration for total growth inhibition: 100000 nM
Estimate against measurement, compound 4: 2.9-fold (0.46 log units) below, and the stated range covers the measured number.
By their numbers in this assay, from the lowest: compounds 1, 2, 3 and 4 (each within the scatter of the next, the first and the last beyond it).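

In this assay, among these compounds, the swap of 2,5-dimethoxyphenyl for 2,5-dihydroxyphenyl gives a 2.2-fold higher number from compound 2 to compound 4 (0.35 log units; beyond the scatter) and is the only step in this set that lies beyond the scatter, though it is modest in size. The two earlier steps, on the sulfonamide nitrogen and on the phenyl group, did not show that a single change to this core could move the number past the scatter; this one does so on the aromatic carbon next to the ring nitrogen, and the move is toward weaker inhibition of growth. The entering group carries hydrogen-bond donors and the leaving group carries none, but nothing given here links that difference to the result, and no supporting measurement explains the step.

Both methoxy groups change together in this pair, so the compounds shown leave open whether one of them alone accounts for the step, as a phenyl ring carrying one hydroxy and one methoxy group would test. They also leave open how other groups on this ring, such as an amine or a carboxylic acid, would compare, and whether the same swap would give a similar step in the chloro-substituted compound 3 or the free sulfonamide compound 1.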